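Trifluoromethyl to Phenyl: A Larger Exchange on the Shared Core

This account rests on a few compounds, and the source may have more. Where it says the series, first, only, none or still open, it means among the compounds named here.

In a functional assay on HL-60 cells (Homo sapiens) for cytotoxicity, read by luminescence and CellTiter-Glo, with a stated time of 3 days (on this read-out higher numbers stand for weaker inhibition and lower numbers for stronger inhibition), compound 1 (`N#Cc1ccc(NC(=O)c2ccc(Cl)cc2O)cc1`) gives 1300 nM and compound 2 (`N#Cc1ccc(NC(=O)c2ccc(C(F)(F)F)cc2O)cc1`) gives 1030 nM so compound 2 stands level with compound 1 within the scatter of repeated measurements. Among the compounds with values here, only one measured step connects them. Trifluoromethyl in place of chloro on an aromatic carbon gives a 1.3-fold lower number from compound 1 to compound 2 (0.10 log units; within the scatter) and thus no real change.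

Compound 3 (`N#Cc1ccc(NC(=O)c2ccc(-c3ccccc3)cc2O)cc1`) has phenyl in place of trifluoromethyl on an aromatic carbon and keeps the rest of the shared core. Within the data shown here, no measured compound carries a ring at this place, so the evidence for this exchange is thin. Among the measured compounds shown here, the single guide is a 1.3-fold lower number from compound 1 to compound 2 (0.10 log units; within the scatter) and it shows only that one exchange of a small group left the number in the same range. On that basis, no step beyond the scatter is expected in this assay and a wide range is warranted. The expected change is a 1.1-fold lower number from compound 2 to compound 3 (0.06 log units; within the scatter) and this remains an estimate. The estimated value for compound 3 is 900 nM with an expected range from 300 nM to 2700 nM until the measurement is known.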

Compound 3, half-maximal inhibitory concentration: 700 nM
Compound 3: the middle estimate sits 1.3-fold (0.11 log units) above what was measured; the measured number falls inside the stated range.
By their numbers in this assay, from the lowest: compounds 3, 2 and 1 (each within the scatter of the next).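

In this assay, the exchange of trifluoromethyl for phenyl gives a 1.5-fold lower number from compound 2 to compound 3 (0.17 log units; within the scatter) and places a six-membered aromatic ring of carbon only on this aromatic carbon, while the exchange of chloro for phenyl gives a 1.9-fold lower number from compound 1 to compound 3 (0.27 log units; within the scatter) on the same carbon. Neither step leaves the scatter, so this position, meta to a hydroxy group and para to a large group, holds a phenyl ring with no real change in the number, something the earlier pair of compounds, neither of which has a ring here, could not show. Nothing measured here bears on why the number stays in the same range across these three compounds.

Trifluoromethyl and phenyl both lack hydrogen-bond donors, hydrogen-bond acceptors and a net charge, so it remains open whether an amine, a carboxylic acid or a longer alkyl chain on this carbon would give a step beyond the scatter. On these data alone, it also remains open whether a methoxy group in place of the hydroxy group would keep the number in this range, as all three compounds share the rest of the core.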